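This account rests on a few compounds, and the source may have more. Where it says the series, first, only, none or still open, it means among the compounds named here.

Measured compounds:
- compound 1, `O=C1O[C@H]([C@@H](O)Cn2cc(-c3cc(C(F)(F)F)cc(C(F)(F)F)c3)nn2)C(OCc2ccccc2)=C1OCc1ccccc1`: 80700 nM
- compound 2, `CC(C)(C)c1cn(C[C@H](O)[C@H]2OC(=O)C(OCc3ccccc3)=C2OCc2ccccc2)nn1`: 13300 nM

In an ADME assay on HFF cells (Homo sapiens) for cytotoxicity, read by MTT assay, with a stated time of 72 h (a higher number here means a weaker inhibitor, a lower number a stronger inhibitor), compound 2 gives 13300 nM, the lowest of the two numbers; compound 1 gives 80700 nM, a gap that lies beyond the scatter. Compound 3, `Cc1ccc(S(=O)(=O)NCc2cn(C[C@H](O)[C@H]3OC(=O)C(OCc4ccccc4)=C3OCc3ccccc3)nn2)cc1`, has not yet been measured in this assay. It differs from compound 2 in one place: (((4-methylphenyl)sulfonyl)amino)methyl in place of tert-butyl on an aromatic carbon. Within the data shown here, no measured pair in this set shows what this kind of change does, so the direction of the step is not known from the data. The account expects a step from compound 2 to compound 3 that stays within the scatter or rises only modestly, a 1.5-fold higher number from compound 2 to compound 3 (0.18 log units; within the scatter). The estimate for compound 3 in this assay is therefore 20000 nM, with a range from 6000 nM to 70000 nM.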

Compound 3, half-maximal inhibitory concentration: 50 nM
The estimate for compound 3 lay 400-fold (2.60 log units) above the measured number, outside the stated range (below it).
By their numbers in this assay, from the lowest: compound 3; then compound 2; then compound 1.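

In this assay, (((4-methylphenyl)sulfonyl)amino)methyl in place of tert-butyl on an aromatic carbon gives a 270-fold lower number from compound 2 to compound 3 (2.42 log units; beyond the scatter), which shows that with the rest of the molecule unchanged, this position alone can shift the cytotoxicity number by a large margin. The change replaces a group with no ring and no hydrogen-bond donors or acceptors with one that has a six-membered aromatic ring of carbon only as well as hydrogen-bond donor and acceptor capacity, and this single step cannot separate the contributions of those parts. Nothing available here accounts for the size of the step.

The compounds shown leave open which part of the entering group carries the step. A plain aminomethyl group or a benzyl group on the same aromatic carbon could help to separate the sulfonyl nitrogen portion from the aromatic ring.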